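An Aryl Swap at the Assay Limit

This account rests on a few compounds, and the source may have more. Where it says the series, first, only, none or still open, it means among the compounds named here.

Compound 1 `C/C(=C\CC/C(C)=C/CC[C@@H]1[C@@]2(C)CCC(=O)C(C)(C)[C@H]2CC[C@@]1(C)O)CC/C=C(\C)C(=O)OCc1cn(-c2ccc(C(F)(F)F)cc2)nn1` gives > 150000 nM in a functional assay on A549 cells (Homo sapiens) for antiproliferative activity, read by MTT assay, with a stated time of 48 h (on this read-out lower numbers stand for stronger inhibition and higher numbers for weaker inhibition), a limit of the assay and not a number.
Compound 2 `C/C(=C\CC/C(C)=C/CC[C@@H]1[C@@]2(C)CCC(=O)C(C)(C)[C@H]2CC[C@@]1(C)O)CC/C=C(\C)C(=O)OCc1cn(-c2ccc(F)c(Cl)c2)nn1` gives > 150000 nM in this assay, again a limit.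
Compound 3 `C/C(=C\CC/C(C)=C/CC[C@@H]1[C@@]2(C)CCC(=O)C(C)(C)[C@H]2CC[C@@]1(C)O)CC/C=C(\C)C(=O)OCc1cn(C[C@@H]2O[C@H](n3ccc(=O)[nH]c3=O)[C@H]3OC(C)(C)O[C@H]32)nn1` gives 15300 nM in this assay.

Compound 2 therefore stands only at a limit; one further value shown, that of compound 1, is also a limit, both resting at the limit of > 150000 nM in this assay, at which 2 of the 3 values shown sit. Going by the values given here, the single step between measured compounds, a step that the two limits leave unreadable from compound 1 to compound 2, is thus unreadable. Compound 4 `C/C(=C\CC/C(C)=C/CC[C@@H]1[C@@]2(C)CCC(=O)C(C)(C)[C@H]2CC[C@@]1(C)O)CC/C=C(\C)C(=O)OCc1cn(-c2ccccc2Cl)nn1` differs from compound 2 by 2-chlorophenyl in place of 3-chloro-4-fluorophenyl on an aromatic nitrogen. No readable step bears on this change, so the writer expects a step of a number no higher from compound 2 to compound 4 (the limit leaves the size open) of no size beyond the scatter, most likely another limit. Compound 4 is estimated at 150000 nM in this assay, within 50000 nM to 400000 nM.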

Compound 4, half-maximal inhibitory concentration: > 150000 nM
Compound 4 ended at the assay's limit (the forecaster's own chance of this, stated with the estimate: 75%); the middle value lies on the limit itself.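

No step among compound 1, compound 2 and compound 4 can be read, since all three values are limits: the limit of > 150000 nM in this assay, at which 3 of the 4 values shown sit.

The compounds shown leave open how these three aryl groups rank in this assay.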